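A Fluoro in Place of Trifluoromethoxy on One Core

This account rests on a few compounds, and the source may have more. Where it says the series, first, only, none or still open, it means among the compounds named here.

Three compounds built on one shared core differ only in the group on a six-membered aromatic ring of carbon only: compound 1 `COc1ccc(Nc2cc(-c3ccncc3)ncn2)cc1` carries methoxy, compound 2 `FC(F)(F)c1ccc(Nc2cc(-c3ccncc3)ncn2)cc1` trifluoromethyl and compound 3 `FC(F)(F)Oc1ccc(Nc2cc(-c3ccncc3)ncn2)cc1` trifluoromethoxy. In an ADME assay on BaF3 cells (Mus musculus) for cytotoxicity (on this read-out lower numbers stand for an effect already at smaller amounts and higher numbers for an effect only at larger amounts of compound), compound 1 gives > 10000 nM, which is a limit of the assay rather than a number. Compound 2 gives > 10000 nM, again only a limit. Compound 3 likewise gives > 10000 nM, a limit and not a measured number. Because all three sit at the limit of > 10000 nM in this assay, at which 3 of the 3 values shown sit, the steps a step that the two limits leave unreadable from compound 1 to compound 2, a step that the two limits leave unreadable from compound 1 to compound 3 and a step that the two limits leave unreadable from compound 2 to compound 3 cannot be read in size or direction.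

Compound 4 `Fc1ccc(Nc2cc(-c3ccncc3)ncn2)cc1` differs from compound 3 by fluoro in place of trifluoromethoxy on an aromatic carbon. Among the measured compounds shown here, the only steps that bear on this change are the three among compounds 1, 2 and 3, and none of them yields a readable size, so no measured step points to a gain or a loss in this assay. Compound 3 stands at the limit, and the expectation is that compound 4 stays near it, with an estimated step that the limit leaves unreadable from compound 3 to compound 4. Compound 4 is therefore estimated at 15000 nM, within a range from 5000 nM to 50000 nM.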

Compound 4, half-maximal effective concentration: > 10000 nM
Compound 4: only a limit was reported; the forecaster's own chance of this, stated with the estimate: 80%; the middle value does not contradict the limit.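

In this assay compound 4 gives > 10000 nM, which is a limit and not a number. The steps from compound 1, compound 2 and compound 3 to compound 4 cannot be read in size or direction, because all of these compounds share one limit: the limit of > 10000 nM in this assay, at which 4 of the 4 values shown sit. The compounds shown leave open whether any group at this place on the shared core would give an effect at smaller amounts of compound.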